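A 4-methoxybenzyl group on compound 3

The source may report more compounds than this note shows. Statements on the series, on what has been measured and on what is new or still open speak of the compounds shown alone.

In a functional assay on PC-3 cells (Homo sapiens) for cytotoxicity, read by WST assay, with a stated time of 24 h (a lower number here means a stronger inhibitor, a higher number a weaker inhibitor), compound 3 (`COc1ccc2c(C(=O)/C(C#N)=C/c3c[nH]c4ccccc34)c[nH]c2c1`) reads > 50000 nM as a limit, not a number. Compound 1 (`COc1ccc2c(/C=C(\C#N)C(=O)c3c[nH]c4cc(OC)ccc34)c[nH]c2c1`) shows > 50000 nM as a limit too. Compound 2 (`COc1ccc2c(C(=O)/C(C#N)=C/c3cn(Cc4ccc(Cl)cc4)c4ccccc34)c[nH]c2c1`) shows > 50000 nM as a limit too. Going by the values given here, the series so far offers only the limit of > 50000 nM in this assay, at which 3 of the 3 values shown sit, and no number. Compound 4 (`COc1ccc(Cn2cc(/C=C(\C#N)C(=O)c3c[nH]c4cc(OC)ccc34)c3ccccc32)cc1`) has 4-methoxybenzyl in place of hydrogen on an aromatic nitrogen. The nearest measured change, hydrogen in place of 4-chlorobenzyl on the same kind of nitrogen, is a step that the two limits leave unreadable from compound 2 to compound 3 and has no size. Hydrogen in place of methoxy on an aromatic carbon is a step that the two limits leave unreadable from compound 1 to compound 3 and is equally silent. No clear step in either direction is therefore expected in this assay on this evidence. The estimated change is a number no higher from compound 3 to compound 4 (the limit leaves the size open) in size. For compound 4 the estimate is 50000 nM with an expected range from 20000 nM to 100000 nM and another limit is the likeliest reading.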

Compound 4, half-maximal inhibitory concentration: > 50000 nM
Compound 4 ended at the assay's limit; the forecaster's own chance of this, stated with the estimate: 85%; the middle value lies on the limit itself.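

Compound 4 reads as a limit, as do compound 2 and compound 3, so neither step to compound 4 can be read. The compounds shown leave open how strongly any of them acts in this assay, because all rest on one limit: the limit of > 50000 nM in this assay, at which 4 of the 4 values shown sit.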